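A Smaller Ring at the Ether Carbon

The source may report more compounds than this note shows. Statements on the series, on what has been measured and on what is new or still open speak of the compounds shown alone.

Measured so far, in a functional assay on cells for antagonist activity at Glucagon receptor (Homo sapiens), read by cAMP accumulation, in the presence of a further agent that is not named here; a higher number here means a weaker inhibitor, a lower number a stronger inhibitor:
Compound 1, `CCCC(Oc1ccc(-n2cc(C(F)(F)F)cn2)c(C)c1)c1ccc(C(=O)NCCC(=O)O)cc1`, gives 1900 nM.
Compound 2, `O=C(O)CCNC(=O)c1ccc(C(Oc2ccc(-n3cc(C(F)(F)F)cn3)cc2)C2CCCC2)cc1`, gives 4000 nM.
Compound 3, `CCCC(Oc1ccc(-n2cc(C(F)(F)F)cn2)nc1)c1ccc(C(=O)NCCC(=O)O)cc1`, gives 3700 nM.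

Compound 2 shows the highest number of the three. Compound 3 lies within the usual scatter of it, so the two cannot be told apart, while compound 1 sits beyond the scatter with a lower number, a stronger inhibitor. Compound 4, `O=C(O)CCNC(=O)c1ccc(C(Oc2ccc(-n3cc(C(F)(F)F)cn3)cc2)C2CCC2)cc1`, has not yet been measured. It differs from compound 2 in one place: cyclobutyl in place of cyclopentyl on a saturated chain carbon bound to an aromatic carbon and an oxygen on an aromatic ring. For the measured compounds named here, with no single-change steps among the measured compounds to lean on, the expected step in this assay is none beyond the scatter, in either direction. Compound 4 is therefore estimated at 4000 nM, within a range of 1800 nM to 9000 nM. This estimate means an expected step of no change at the digits printed from compound 2 to compound 4 (within the scatter).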

Compound 4, antagonist equilibrium constant: 3000 nM
For compound 4 the middle estimate is 1.3-fold (0.12 log units) above the measured one; measured number inside the range.
By their numbers in this assay, from the lowest: compounds 1, 4, 3 and 2 (each within the scatter of the next, the first and the last beyond it).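

Cyclobutyl in place of cyclopentyl on this saturated chain carbon gives a 1.3-fold lower number from compound 2 to compound 4 (0.12 log units; within the scatter) in this assay. For the compounds shown here, this is the first single-change step at this position, and it shows that one ring size can stand in for the other here with no difference that can be told from repeat measurements. No measured evidence explains this result.

The compounds shown leave open how cyclopropyl or cyclohexyl would read on this carbon. They also leave open whether a ring bearing an amine would read the same.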